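Series notes: ring swap on the thiocarbonyl of compound 3

The source may report more compounds than this note shows. Statements on the series, on what has been measured and on what is new or still open speak of the compounds shown alone.

Compound 3 `N/C(=N\NC(=S)N1CCSCC1)c1ccc(F)cn1` gives 55.1% in a functional assay on A-375 cells (Homo sapiens) for cytotoxicity, read by MTT assay, with a stated time of 72 h, tested at 1 uM (on this read-out lower numbers stand for less inhibition of growth and higher numbers for more inhibition of growth at the one concentration tested), the second highest of the three numbers measured. Compound 2 `N/C(=N\NC(=S)N1CCCC1)c1ccc(F)cn1` gives 57.9%, a difference within the scatter, while compound 1 `N/C(=N\NC(=S)N1CCOCC1)c1ccccn1` gives 26.8%, the lowest figure. Compound 4 `N/C(=N\NC(=S)N1CCOCC1)c1ccc(F)cn1` differs from compound 3 in one place: morpholin-4-yl in place of thiomorpholin-4-yl on a thiocarbonyl carbon. Going by the values given here, the only measured step on the same position is a number 2.8 percentage points lower from compound 2 to compound 3 (within the scatter), which suggests that exchanging the group on the thiocarbonyl carbon has little effect. Compound 1 also carries morpholin-4-yl but lacks the fluorine of compound 3, so it offers no direct comparison. Compound 4 is therefore expected to stay close to compound 3, with a step of a number 5.1 percentage points lower from compound 3 to compound 4 (within the scatter) in this assay. The estimate for compound 4 is 50%, ranging from 28% to 66%.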

Compound 4, percent growth inhibition at one concentration: 44.5%
The estimate for compound 4 lay 5.5 percentage points above the measured number; low and high end bracket the measured number.
By their numbers in this assay, from the lowest: compound 1; then compound 4; then compounds 3 and 2 (each within the scatter of the next).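

In this assay the group on the thiocarbonyl carbon does count, with a number 10.6 percentage points lower from compound 3 to compound 4 (beyond the scatter) and a number 13.4 percentage points lower from compound 2 to compound 4 (beyond the scatter) once morpholin-4-yl enters, while thiomorpholin-4-yl and pyrrolidin-1-yl remain within the scatter of each other. Going by these compounds alone, with morpholin-4-yl on both compounds, fluoro in place of hydrogen on an aromatic carbon gives a number 17.7 percentage points higher from compound 1 to compound 4 (beyond the scatter) as the first reading of that change. Nothing at hand gives a reason for these steps.

Open, as far as these compounds go, is how a piperidin-1-yl ring or a dimethylamino group on the thiocarbonyl carbon would compare. Also open, from the compounds shown here alone, is whether the fluoro step holds with pyrrolidin-1-yl or thiomorpholin-4-yl.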